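Fluoro to hydrogen on the benzylamino arm

The source may report more compounds than this note shows. Statements on the series, on what has been measured and on what is new or still open speak of the compounds shown alone.

Two members of the series have been read in an ADME assay on Vero cells (Chlorocebus sabaeus) for cytotoxicity, read by MTT assay, with a stated time of 48 h; on this read-out lower numbers stand for stronger inhibition and higher numbers for weaker inhibition. Compound 1, `CN(Cc1ccc2c(c1)OCCO2)c1nc(=O)c2cc(C(F)(F)F)cc([N+](=O)[O-])c2o1`, gives 9.27 ug/mL in this assay. Compound 2, `O=c1nc(NCc2cccc(F)c2)oc2c([N+](=O)[O-])cc(C(F)(F)F)cc12`, returns only a limit of the assay in this assay, > 64 ug/mL. Going by the values given here, compound 2 thus sits at the limit of > 64 ug/mL in this assay, at which 1 of the 2 values shown sits, and it is the one member of the pair without a settled number.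

Compound 3, `O=c1nc(NCc2ccccc2)oc2c([N+](=O)[O-])cc(C(F)(F)F)cc12`, has not been run in this assay. It differs from compound 2 by hydrogen in place of fluoro on an aromatic carbon.

Among the compounds with values here, no pair of measured compounds differs in one place, so no measured step in this assay anchors the expectation for this change. The change itself is the loss of a single fluorine and nothing more. For compound 3 the expected step is a number no higher from compound 2 to compound 3 (the limit leaves the size open), which is to say none beyond the scatter, and a second limit rather than a number is the likelier outcome. Compound 3 is estimated at 64 ug/mL in this assay, with a range from 32 ug/mL to 128 ug/mL.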

Compound 3, half-maximal inhibitory concentration: 25.4 ug/mL
For compound 3 the middle estimate is 2.5-fold (0.40 log units) above the measured one; measured number below the stated range.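

In this assay, going by these compounds alone, the change from (3-fluorobenzyl)amino to benzylamino gives an at least 2.5-fold lower number from compound 2 to compound 3 (0.40 log units; beyond the scatter), the only step so far that can be read between compounds differing in one place. This aromatic carbon, meta to a large group, is therefore not a silent position on this read-out: exchanging fluoro for hydrogen, with no other change to the structure, moves the number beyond the usual scatter and towards stronger inhibition, and it turns a result with no settled number into a measured one. Compound 2 stands at a limit of the assay rather than at a number, so the step has a lower bound on its size and no upper bound: the limit of > 64 ug/mL in this assay, at which 1 of the 3 values shown sits.

The compounds shown do not tell whether this shift belongs to fluoro in particular or would also appear with another group on the same aromatic carbon, such as chloro, methoxy or a nitrile. They also leave open whether the same exchange would give a step of similar size on another member of the series, since this change has been read on a single pair.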